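The compounds below may be only part of what the source reports. "The series", "measured", "known", "first", "only" and "open" are said of these compounds alone.

Measured compounds in a physicochemical assay for acid dissociation:
compound 1 `Fc1ccc(-c2ccc3c(NCCCNCc4ccco4)ccnc3c2)cc1` gives 9.47;
compound 2 `COc1cccc(CNCCCNc2ccnc3cc(-c4ccc(F)cc4)ccc23)c1O` gives 9.47;
compound 3 `COc1ccc(F)cc1CNCCCNc1ccnc2cc(Cc3ccccc3)ccc12` gives 9.47.

Compound 1 stands level with compounds 2 and 3 at the digits shown; its nearest neighbour is compound 2 and its furthest is compound 3, and in both cases the difference is within the scatter. Going by the values given here, the one step recorded between two measured compounds that differ in a single place, no change at the digits printed from compound 1 to compound 2 (within the scatter), is no change within the scatter; that step alters the group on a saturated chain carbon bound to an amine nitrogen, not the aromatic carbon of the shared core.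

Compound 4 `Clc1ccc(Oc2ccc3c(NCCCNCc4ccco4)ccnc3c2)cc1` is not yet measured. It differs from compound 1 as follows: 4-chlorophenoxy in place of 4-fluorophenyl on an aromatic carbon. Among the compounds with values here, no recorded step touches this position directly. What can be said is that compounds 1 and 3 carry different groups on the core and show the same value, and that the step from compound 1 to compound 2 leaves the number unchanged, so no step beyond the scatter in this assay is expected from this change either.

For compound 4 the expected step of no change at the digits printed from compound 1 to compound 4 (within the scatter) is none beyond the scatter; the estimate for compound 4 is 9.47, in a range from 9.1 to 9.85.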

Compound 4, acid dissociation constant: 9.28
Beside the measured number, compound 4's estimate is 0.19 log units above it; low and high end bracket the measured number.
By their numbers in this assay, from the lowest: compounds 4, 1, 2 and 3 (each within the scatter of the next).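

In this assay, this position on an aromatic carbon of the shared core now has its first recorded step, a number 0.19 log units lower from compound 1 to compound 4 (within the scatter), with 4-chlorophenoxy in place of 4-fluorophenyl. This single exchange brings in one hydrogen-bond acceptor where the leaving group counts none, and eight heavy atoms in place of seven, yet the read-out stays within the scatter. Compound 1 now has a step at the core as well as at the saturated chain carbon bound to an amine nitrogen, where no change at the digits printed from compound 1 to compound 2 (within the scatter) is printed, and neither step goes beyond the scatter; no measurement at hand bears on the reason for this.

The step changes the halogen and the attachment through oxygen together, so the compounds shown cannot separate the two, and 4-chlorophenyl or 4-fluorophenoxy at this position would be needed to do so. Both groups compared also carry a six-membered aromatic ring of carbon only, which leaves open whether an amine or a carboxylic acid at this position would also stay within the scatter.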